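Swapping the anilide aryl group on a shared naphthyl-thiazolidinedione core

The source may report more compounds than this note shows. Statements on the series, on what has been measured and on what is new or still open speak of the compounds shown alone.

Measured compounds:
compound 1, `Cc1ccc(NC(=O)COc2ccc3cc(/C=C4/SC(=O)NC4=O)ccc3c2)cc1Cl`, 1100 nM;
compound 2, `Cc1cccc2sc(NC(=O)COc3ccc4cc(/C=C5/SC(=O)NC5=O)ccc4c3)nc12`, 1200 nM;
compound 3, `COc1ccc(NC(=O)COc2ccc3cc(/C=C4/SC(=O)NC4=O)ccc3c2)cc1`, 4700 nM.

In an assay on isolated protein for inhibition of histone deacetylase 4 (Homo sapiens), with a stated time of 1 h (on this read-out lower numbers stand for stronger inhibition and higher numbers for weaker inhibition), compound 1 gives the lowest of the three numbers. Compound 2 sits within the scatter of it, as a 1.1-fold higher number from compound 1 to compound 2 (0.04 log units; within the scatter) shows, while compound 3 lies further off, with a 4.3-fold higher number from compound 1 to compound 3 (0.63 log units; beyond the scatter). Compound 4, `O=C(COc1ccc2cc(/C=C3/SC(=O)NC3=O)ccc2c1)Nc1ccc(F)cc1F`, differs from compound 1 in one place: 2,4-difluorophenyl in place of 3-chloro-4-methylphenyl on an amide-type nitrogen. Going by the values given here, the steps that bear on this change both alter the group on the amide-type nitrogen; a 1.1-fold higher number from compound 1 to compound 2 (0.04 log units; within the scatter) was within the scatter and a 4.3-fold higher number from compound 1 to compound 3 (0.63 log units; beyond the scatter) was modest. A small to modest rise in the number is therefore expected for compound 4, a 1.6-fold higher number from compound 1 to compound 4 (0.21 log units; within the scatter). Compound 4 is estimated at 1800 nM, with a range from 800 nM to 4500 nM.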

Compound 4, half-maximal inhibitory concentration: 3900 nM
Estimate against measurement, compound 4: 2.2-fold (0.34 log units) below, within the range that was stated.
By their numbers in this assay, from the lowest: compounds 1 and 2 (each within the scatter of the next); then compounds 4 and 3 (each within the scatter of the next).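

Exchanging 3-chloro-4-methylphenyl for 2,4-difluorophenyl keeps the count of heavy atoms and the single carbon-only aromatic ring, yet gives a 3.5-fold higher number from compound 1 to compound 4 (0.55 log units; beyond the scatter), so the number at this amide-type nitrogen moves even when those counts stay the same. The fluorinated compound also separates from the benzothiazolyl one, with a 3.3-fold higher number from compound 2 to compound 4 (0.51 log units; beyond the scatter), but not from the methoxy one, with a 1.2-fold lower number from compound 3 to compound 4 (0.08 log units; within the scatter). Nothing available explains these differences. The compounds shown leave open whether chlorine or methyl alone would match compound 1, and how an amine or a carboxylic acid on the phenyl ring would read.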